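The source may hold more compounds than are shown below. What is called first, only, known or untested is meant among the compounds shown, and "the series" means these compounds.

Measured in a functional assay on MDA-MB-231 cells (Homo sapiens) for inhibition, read by MTT assay, with a stated time of 48 h; on this read-out higher numbers stand for weaker inhibition and lower numbers for stronger inhibition:
- compound 1 `COc1cc(-c2cc(-c3ccc(Br)cc3)nc(-c3ccccc3)n2)cc(OC)c1OC`: > 25000 nM, a limit of the assay and not a number
- compound 2 `COc1cc(-c2cc(-c3ccc(C)cc3)nc(-c3ccccc3)n2)cc(OC)c1OC`: 5110 nM
- compound 3 `COc1cc(-c2cc(-c3ccccc3)nc(-c3ccccc3)n2)cc(OC)c1OC`: 5870 nM

Compound 3 carries a plain phenyl group, and its number cannot be told apart from that of compound 2: the measured step is a 1.1-fold higher number from compound 2 to compound 3 (0.06 log units; within the scatter). Compound 4 `COc1cc(-c2cc(-c3ccc(O)cc3)nc(-c3ccccc3)n2)cc(OC)c1OC` is compound 3 with one small change, hydroxy in place of hydrogen on an aromatic carbon. The hydroxy sits on an aromatic carbon, para to a large group, which turns phenyl into 4-hydroxyphenyl.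

Among the measured compounds shown here, two measured steps touch this same place. Replacing methyl with hydrogen gave the step already shown, which is within the scatter. Replacing bromo with hydrogen gave an at least 4.2-fold lower number from compound 1 to compound 3 (0.62 log units; beyond the scatter), and the matching change to methyl gave an at least 4.8-fold lower number from compound 1 to compound 2 (0.68 log units; beyond the scatter). So a group here has either made no clear difference or gone with a clearly weaker result, and none has clearly improved on compound 3. For the measured compounds named here, no measured compound carries a hydroxy, so this guide is loose. The most likely outcome is therefore no change beyond the scatter, with some risk of weaker inhibition. The expected step is a 1.1-fold higher number from compound 3 to compound 4 (0.04 log units; within the scatter). For compound 4 the estimated value is 6500 nM, with an expected range from 2500 nM to 22000 nM.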

Compound 4, half-maximal inhibitory concentration: 1600 nM
Estimate against measurement, compound 4: 4.1-fold (0.61 log units) above; the measured number lies below the stated range.
By their numbers in this assay, from the lowest: compound 4; then compounds 2 and 3 (each within the scatter of the next). At a limit, above all of these: compound 1.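

In this assay, among the compounds shown here, the change to 4-hydroxyphenyl gives a 3.7-fold lower number from compound 3 to compound 4 (0.56 log units; beyond the scatter) and so shows for the first time that a group at this place on the ring can go with clearly stronger inhibition, something neither methyl nor bromo showed against the plain phenyl group. The hydroxy group also gives a 3.2-fold lower number from compound 2 to compound 4 (0.50 log units; beyond the scatter) and an at least 15-fold lower number from compound 1 to compound 4 (1.19 log units; beyond the scatter) so compound 4 stands clearly ahead of all three earlier compounds, and a small swap on this ring now spans the whole range seen so far. The step from compound 1 starts from a limit of the assay and not a number: the limit of > 25000 nM in this assay, at which 1 of the 4 values shown sits.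

What the compounds shown leave open is why hydroxy differs from methyl and bromo, and whether the gain depends on the hydroxy itself, since a methoxy group or an amine at the same place could show whether a similar small group does as well. They also do not tell whether a carboxylic acid, or a longer chain ending in a hydroxy group, would keep the gain, lose it or extend it.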